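The source may report more compounds than this note shows. Statements on the series, on what has been measured and on what is new or still open speak of the compounds shown alone.

In an assay on cells for displacement of a labelled ligand from prostaglandin E2 receptor EP4 subtype (Homo sapiens), read by scintillation counting (a lower number here means a stronger inhibitor, a higher number a weaker inhibitor), compound 1, with the structure `COc1ccc(-c2ccc(OCc3cc(C(=O)NS(=O)(=O)c4ccc(CN)cc4)oc3C)cc2)cc1`, gives 100 nM. Two related compounds lack the acylsulfonamide portion of compound 1 and end instead in a carboxylic acid: compound 2 `COc1ccccc1-c1ccc(OCc2cc(C(=O)O)oc2C)cc1` gives 1600 nM in this assay, and compound 3 `Cc1oc(C(=O)O)cc1COc1ccc(-c2ccc(C#N)cc2)cc1` gives 1500 nM. Among the compounds with values here, the only single-point change among the measured compounds, a 1.1-fold lower number from compound 2 to compound 3 (0.03 log units; within the scatter), concerns the far end of the molecule and leaves the number essentially unchanged. Compound 1 therefore stands with the lowest number of the three, and both compound 2 and compound 3 sit well above it.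

Compound 4, with the structure `COc1ccc(-c2ccc(OCc3cc(C(=O)NS(=O)(=O)c4ccccc4)oc3C)cc2)cc1`, differs from compound 1 by hydrogen in place of aminomethyl on an aromatic carbon. Within the data shown here, no measured step touches this part of the molecule: the one step available, from compound 2 to compound 3, alters the other end and stays within the scatter. The expectation for compound 4 can rest only on compound 1 itself, which already gives 100 nM, so a step of a 2.0-fold higher number from compound 1 to compound 4 (0.30 log units; within the scatter) is expected, a modest rise in the number rather than a large one. On that basis compound 4 is estimated at 200 nM, with a plausible range from 60 nM to 700 nM.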

Compound 4, inhibition constant in the prostaglandin E2 receptor EP4 subtype assay: 5 nM
Compound 4: the middle estimate sits 40-fold (1.60 log units) above what was measured, outside the stated range (below it).
By their numbers in the prostaglandin E2 receptor EP4 subtype assay, from the lowest: compound 4; then compound 1; then compounds 3 and 2 (each within the scatter of the next).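

Hydrogen in place of aminomethyl on this aromatic carbon gives a 20-fold lower number from compound 1 to compound 4 (1.30 log units; beyond the scatter), so this position strongly affects the number in the prostaglandin E2 receptor EP4 subtype assay, something the only earlier step, which involved a different change, could not show. In a physicochemical assay for solubility, in phosphate buffer, with a stated time of 24 h, at pH 7.4 (a higher number here means a more soluble compound, a lower number a less soluble compound), compound 1 gives < 0.6 ug/mL, which is a limit of the assay and not a number. In the physicochemical assay compound 4 gives 11 ug/mL. The same change that lowers the binding number also raises the solubility, so for this pair the two read-outs improve together, as the measured values show: the measured solubility of compound 1, < 0.6 ug/mL, and of compound 4, 11 ug/mL, an at least 18-fold higher number (1.26 log units; beyond the scatter)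

The compounds shown carry only hydrogen and aminomethyl at this position, so it remains open whether the weaker binding of compound 1 comes from the amine itself or would follow from any group placed there, a question that a methyl group, a chlorine atom or a longer aminoethyl chain could help to answer. From the compounds shown here alone, it also remains open how the rest of the phenylsulfonyl end contributes to the number of compound 4, and whether this change would have the same effect on a different core.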